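This account rests on a few compounds, and the source may have more. Where it says the series, first, only, none or still open, it means among the compounds named here.

Measured so far in an in vivo functional assay on the whole organism (Rattus norvegicus) with cysteinyl leukotriene receptor (Homo sapiens) as the target; on this read-out lower numbers stand for an effect already at smaller amounts and higher numbers for an effect only at larger amounts of compound:
compound 1, `CCCc1c(COc2ccc(C(=O)Cc3nnn[nH]3)cc2)ccc(C(C)=O)c1O`, gives 24.1 mg/kg;
compound 2, `CCc1c(COc2ccc(C(=O)CC(C)(C)CC(=O)O)cc2)ccc(C(C)=O)c1O`, gives 1.4 mg/kg.

Of these two numbers compound 2 has the lower one, and compound 1 sits a good way higher; since the two compounds differ in more than one place, that gap cannot be tied to a single change. Compound 3, `CCCc1c(COc2ccc(C(=O)CC(C)(C)CC(=O)O)cc2)ccc(C(C)=O)c1O`, is not yet measured. It differs from compound 2 only by methyl in place of hydrogen on a saturated chain carbon, two bonds along the chain from an aromatic carbon. No single-change comparison is available to lean on. In this assay the expected step is no change at the digits printed from compound 2 to compound 3 (within the scatter), small and within the usual scatter, in no clear direction. Compound 3 is therefore expected to give about 1.4 mg/kg, with a range from 0.5 mg/kg to 4 mg/kg.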

Compound 3, dose for half-maximal effect: 2.9 mg/kg
For compound 3 the middle estimate is 2.1-fold (0.32 log units) below the measured one; the measured number falls inside the stated range.
By their numbers in this assay, from the lowest: compound 2; then compound 3; then compound 1.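

In this assay, methyl in place of hydrogen on a saturated chain carbon, two bonds along the chain from an aromatic carbon, gives a 2.1-fold higher number from compound 2 to compound 3 (0.32 log units; beyond the scatter), so this position responds modestly to one added carbon. With the propyl chain present in both compounds, 1-(carboxymethyl)-1-methylethyl in place of 1H-tetrazol-5-yl gives an 8.3-fold lower number from compound 1 to compound 3 (0.92 log units; beyond the scatter), also a modest step. Nothing available explains either step. As far as these compounds go, whether a butyl chain at this position would shift the number further remains open, as does the effect of a hydroxyl group on that chain.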